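This account rests on a few compounds, and the source may have more. Where it says the series, first, only, none or still open, it means among the compounds named here.

Series notes. Compound 1 `CC1=C(C(=O)OCC(C)C)C(c2cccs2)NC(=O)N1` in an assay on membranes from HeLa cells for displacement of a labelled ligand from adenosine receptor A3 (Homo sapiens), read by scintillation counting, with a stated time of 180 min, tested at 1 uM (a lower number here means less inhibition, a higher number more inhibition at the concentration tested (going by the name of the read-out)), gives 11%. Compound 2 `CC1=C(C(=O)OCc2ccccc2)C(c2cccs2)NC(=O)N1` in this assay gives 8%, the lower of the two numbers, though the step of a number 3 percentage points lower from compound 1 to compound 2 (within the scatter) lies within the scatter. Compound 3 `CC1=C(C(=O)OCc2ccccc2)C(c2ccsc2)NC(=O)N1` differs from compound 2 only in the heteroaryl group: thiophen-3-yl in place of thiophen-2-yl on a saturated ring carbon. Going by the values given here, no measured step touches this position; the only step measured, a number 3 percentage points lower from compound 1 to compound 2 (within the scatter), concerns the ester side and was within the scatter anyway. On that basis no step beyond the scatter is expected, a number 1 percentage points higher from compound 2 to compound 3 (within the scatter). Compound 3 is therefore estimated at 9%, within -3% to 21%, in this assay.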

Compound 3, a percentage reported as inhibition, at one concentration (the size of the read-out at that concentration, not a potency): 25%
Compound 3: the middle estimate sits 16 percentage points below what was measured; the whole stated range lies below it.
By their numbers in this assay, from the lowest: compounds 2 and 1 (each within the scatter of the next); then compound 3.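

In this assay, going by these compounds alone, the group on the saturated ring carbon is the first change to move the number beyond the scatter: thiophen-3-yl in place of thiophen-2-yl gives a number 17 percentage points higher from compound 2 to compound 3 (beyond the scatter) with the ester side unchanged. Both groups have the same atoms and the same counts, so only how the thiophene is joined separates these two compounds. Nothing available explains this step.

From the compounds shown here alone, whether thiophen-3-yl gives a similar step alongside the ester of compound 1 remains open. So does the outcome with furan-3-yl or pyridin-3-yl on this carbon.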